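Hydroxy to methoxy on the shared core: compound 4

The source may hold more compounds than are shown below. What is called first, only, known or untested is meant among the compounds shown, and "the series" means these compounds.

Measured so far in a functional assay on HeLa cells (Homo sapiens) for cytotoxicity, read by WST assay, with a stated time of 48 h; on this read-out lower numbers stand for stronger inhibition and higher numbers for weaker inhibition:
compound 1 `COc1ccc(CCC[C@@H]2C[C@@H]([C@@H](O)c3ccc(OC)c(OC)c3)CO[C@H]2c2ccc(OC)c(OC)c2)cc1OC`: 35700 nM
compound 2 `COc1ccc([C@H](O)[C@H]2CO[C@@H](c3ccc(OC)c(OC)c3)[C@H](C/C=C/c3ccc(OC)c(OC)c3)C2)cc1`: 32200 nM
compound 3 `COc1ccc(/C=C/C[C@@H]2C[C@@H]([C@@H](O)c3ccc(OC)c(OC)c3)CO[C@H]2c2ccc(OC)c(OC)c2)cc1OC`: 30600 nM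

Compound 3 gives the lowest of the three numbers, yet its separation from the others is small: a 1.2-fold lower number from compound 1 to compound 3 (0.07 log units; within the scatter) and a 1.1-fold lower number from compound 2 to compound 3 (0.02 log units; within the scatter) both fall within the scatter, so no ordering among compounds 1, 2 and 3 can be claimed.

Compound 4 `COc1ccc(/C=C/C[C@@H]2C[C@@H]([C@@H](OC)c3ccc(OC)c(OC)c3)CO[C@H]2c2ccc(OC)c(OC)c2)cc1OC` differs from compound 3 by methyl in place of hydrogen on an oxygen on a saturated carbon. Neither measured step concerns this oxygen, so nothing bears directly on it; the two steps known in the series are both within the scatter. By that precedent compound 4 is expected to show a 1.0-fold lower number from compound 3 to compound 4 (0.01 log units; within the scatter), no shift beyond the scatter. Compound 4 is estimated at 30000 nM, range 12000 nM to 80000 nM.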

Compound 4, half-maximal inhibitory concentration: > 100000 nM
Compound 4 gave a limit, no number; the forecaster's own chance of this, stated with the estimate: 10%; middle value at least 3.3-fold (0.52 log units) from the limit.
By their numbers in this assay, from the lowest: compounds 3, 2 and 1 (each within the scatter of the next). At a limit, above all of these: compound 4.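

In this assay, among these compounds, the oxygen on a saturated carbon is the first place where a single change moves the read-out beyond the scatter: an at least 3.2-fold higher number from compound 3 to compound 4 (0.51 log units; beyond the scatter). The two earlier steps, on the chain and on an aromatic carbon, stayed within the scatter, so this hydroxy to methoxy change is the only one shown that separates two compounds. Compound 4 is read only as a limit, so the full size of the step stays unknown: the limit of > 100000 nM in this assay, at which 1 of the 4 values shown sits.

The compounds shown do not tell whether an amine in place of the hydroxy, or an ethoxy, would read like compound 3 or like compound 4.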